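From methoxy to (thiophen-2-yl)sulfanyl on compound 1

A few compounds are considered here, and "the series" means these few. Any claim that something is new, unique, unknown or untested is made for them only; others in the source may bear on it.

Measured so far:
compound 1 `CCC(CC)O[C@@H]1C=C(C(=O)O)C[C@H](NCc2ccc(OC)cc2)[C@H]1NC(C)=O` gives > 200000 nM (a limit)
compound 2 `CCC(CC)O[C@@H]1C=C(C(=O)O)C[C@H](NCc2cccc(OC)c2)[C@H]1NC(C)=O` gives > 200000 nM (a limit)
compound 3 `CCC(CC)O[C@@H]1C=C(C(=O)O)C[C@H](NCc2cccc(SC(C)CC)c2)[C@H]1NC(C)=O` gives > 200000 nM (a limit)

In an ADME assay on cells (Fibroblast, Gallus gallus) for cytotoxicity, read by CCK-8 assay, with a stated time of 48 h (on this read-out lower numbers stand for higher toxicity in this test and higher numbers for lower toxicity in this test), compound 1 gives > 200000 nM and that is a limit, not a number. Compound 2 and compound 3 stand in the same place, so all three share the limit of > 200000 nM in this assay, at which 3 of the 3 values shown sit, and cannot be ranked against one another.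

Compound 4 `CCC(CC)O[C@@H]1C=C(C(=O)O)C[C@H](NCc2ccc(Sc3cccs3)cc2)[C@H]1NC(C)=O` keeps the core of compound 1 but carries (thiophen-2-yl)sulfanyl in place of methoxy on an aromatic carbon, para to a large group ((thiophen-2-yl)sulfanyl in place of methoxy on an aromatic carbon). For the measured compounds named here, two measured steps bear on this. The closer one, where a sulfanyl group also replaces methoxy on an aromatic carbon, is a step that the two limits leave unreadable from compound 2 to compound 3 and the other, which swaps 4-methoxyphenyl for 3-methoxyphenyl, is a step that the two limits leave unreadable from compound 1 to compound 2 as well. Neither has a readable size, so neither offers a direction. No step beyond the usual scatter is therefore expected in this assay and this expectation rests on the limit of > 200000 nM in this assay, at which 3 of the 3 values shown sit, alone. The expected change is a number no higher from compound 1 to compound 4 (the limit leaves the size open) and it remains an estimate. For compound 4 the estimated value is 200000 nM with an expected range from 100000 nM to 400000 nM and another limit would be no surprise.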

Compound 4, half-maximal cytotoxic concentration: > 200000 nM
Compound 4 ended at the assay's limit; the forecaster's own chance of this, stated with the estimate: 75%; the middle value lies on the limit itself.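

In this assay compound 4 gives > 200000 nM, which is a limit and not a number. No size can be read for the change from compound 1 to compound 4, because both compounds sit at the same limit: the limit of > 200000 nM in this assay, at which 4 of the 4 values shown sit. The compounds shown leave open what the actual values are and how they rank against one another.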